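The source may hold more compounds than are shown below. What is called first, only, known or untested is meant among the compounds shown, and "the series" means these compounds.

Of the compounds shown here, three have so far been tested in a functional assay on NCI-H460 cells (Homo sapiens) for antiproliferative activity, read by CCK-8 assay, with a stated time of 72 h, tested at 2 uM; a lower number here means a weaker effect, a higher number a stronger effect of the compound at the concentration tested. Compound 1 `COC(CCn1cnc2c(NCc3ccc(C(=O)Nc4ccccc4N)cc3)nc(Cl)nc21)OC` gives 43.7% and stands highest of the three numbers. Compound 2 `CC(C)n1cnc2c(Nc3ccccc3)nc(NCOCc3ccc(C(=O)Nc4ccccc4N)cc3)nc21` gives 15%, which lies beyond the usual scatter below compound 1, and compound 3 `CC1CCN(c2nc(Cl)nc3c2ncn3Cc2ccc(/C=C/C(=O)Nc3ccccc3N)cc2)CC1` gives 8.24%, furthest below it. None of these measured compounds differ from one another in only one place, so no single step can be read from them. Compound 4 `CCCCn1cnc2c(NCc3ccc(C(=O)Nc4ccccc4N)cc3)nc(Cl)nc21` differs from compound 1 in one place: ethyl in place of dimethoxymethyl on a saturated chain carbon, two bonds along the chain from an aromatic nitrogen. Among the measured compounds shown here, no measured pair shows what such a change does, so the step in this assay is expected to be modest, estimated as a number 3.7 percentage points lower from compound 1 to compound 4 (within the scatter), with no clear direction. Compound 4 is therefore expected to give about 40%, within a range from 20% to 60%.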

Compound 4, a percentage reported as inhibition, at one concentration (the size of the read-out at that concentration, not a potency): 19.7%
For compound 4 the middle estimate is 20.3 percentage points above the measured one; the measured number lies below the stated range.
By their numbers in this assay, from the lowest: compounds 3, 2 and 4 (each within the scatter of the next, the first and the last beyond it); then compound 1.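

In this assay, among the compounds shown here, putting ethyl in place of dimethoxymethyl gives a number 24 percentage points lower from compound 1 to compound 4 (beyond the scatter) and so provides the first single-change comparison in this set, showing that this saturated chain carbon, two bonds along the chain from an aromatic nitrogen, is not indifferent to what it carries. The change removes both oxygen atoms and shortens the group, so two differences travel together. Nothing available explains the drop.

On these data alone, whether the oxygen atoms or the size of the group matters more remains open. An amine, a hydroxyl group or a longer all-carbon chain at this place could help separate the two.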